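Swapping the Ether Link of Compound 1 for a Thioether

The compounds below may be only part of what the source reports. "The series", "measured", "known", "first", "only" and "open" are said of these compounds alone.

Measured compounds in a functional assay on CAKI-1 cells (Homo sapiens) for inhibition, read by sulforhodamine B assay, with a stated time of 48 h; on this read-out higher numbers stand for weaker inhibition of growth and lower numbers for stronger inhibition of growth:
Compound 1, `Nc1cc(N)c2nc(-c3ccccc3)c(Oc3ccc(Cl)c(Cl)c3)nc2c1`, gives only a limit of the assay, < 100000 nM.
Compound 2, `CCOC(=O)[C@H](CCC(=O)O)NC(=O)c1ccc(Sc2nc3cc(N)cc(N)c3nc2-c2ccccc2)cc1`, likewise gives only a limit, < 100000 nM.
Compound 3, `CCOC(=O)[C@H](CCC(=O)O)NC(=O)c1ccc(Oc2nc3cc(N)cc(N)c3nc2-c2ccccc2)cc1`, gives 8710 nM.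

Compound 1 therefore stands at the limit of this assay rather than at a number, as the limit of < 100000 nM in this assay, at which 2 of the 3 values shown sit, records. Compound 3 is the only one of the three to give a number. Compound 4, `Nc1cc(N)c2nc(-c3ccccc3)c(Sc3ccc(Cl)c(Cl)c3)nc2c1`, differs from compound 1 by (3,4-dichlorophenyl)sulfanyl in place of 3,4-dichlorophenoxy on an aromatic carbon. Going by the values given here, no pair of measured compounds traces this exact change, so the size of the step in this assay can only be estimated. Compound 2 carries the thioether link and gives only a limit. Compound 3 carries the ether link and gives a number. Because compound 1 itself reaches only < 100000 nM, there is no measured starting number from which a step could be read. Compound 4 is expected to give 60000 nM, with a range from 10000 nM to 150000 nM, and most likely again only a limit. The expected step that the limit leaves unreadable from compound 1 to compound 4 is none beyond the scatter.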

Compound 4, concentration for total growth inhibition: 37200 nM
Compound 4: the middle estimate sits 1.6-fold (0.21 log units) above what was measured; the measured number falls inside the stated range.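

No step can be read from compound 1 to compound 4, because compound 1 gives a limit and not a number: the limit of < 100000 nM in this assay, at which 2 of the 4 values shown sit.

The compounds shown leave open whether (3,4-dichlorophenyl)sulfanyl in place of 3,4-dichlorophenoxy strengthens inhibition of growth, weakens it or leaves it unchanged.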